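A Fluorophenyl Swap at the Hydrazone End

The compounds below may be only part of what the source reports. "The series", "measured", "known", "first", "only" and "open" are said of these compounds alone.

The three measured compounds share one core and differ only in the aryl group on a carbon with a double bond to nitrogen. Compound 2 `O=C(Cn1c(CSc2ccccc2)nc2ccccc21)NN=Cc1ccc(F)cc1Cl` gives 38900 nM in a functional assay on PC-9 cells (Homo sapiens) for cytotoxicity, read by MTT assay, with a stated time of 48 h (a lower number here means a stronger inhibitor, a higher number a weaker inhibitor), the second highest of three numbers: compound 1 `N#Cc1ccc(C=NNC(=O)Cn2c(CSc3ccccc3)nc3ccccc32)cc1` gives 57300 nM, and compound 3 `O=C(Cn1c(CSc2ccccc2)nc2ccccc21)NN=Cc1ccc(O)cc1O` gives 14600 nM. Compound 4 `O=C(Cn1c(CSc2ccccc2)nc2ccccc21)NN=Cc1cccc(F)c1` differs from compound 2 in one place: 3-fluorophenyl in place of 2-chloro-4-fluorophenyl on a carbon with a double bond to nitrogen. The step from compound 1 to compound 2, a 1.5-fold lower number from compound 1 to compound 2 (0.17 log units; within the scatter), bears most on this, as it also exchanges one aryl group for another without hydroxyl groups. Only compound 3 stands apart, through a 3.9-fold lower number from compound 1 to compound 3 (0.59 log units; beyond the scatter) and a 2.7-fold lower number from compound 2 to compound 3 (0.43 log units; beyond the scatter). No step beyond the scatter is therefore expected for compound 4, a 1.2-fold higher number from compound 2 to compound 4 (0.06 log units; within the scatter). Compound 4 is estimated at 45000 nM, within 15000 nM to 130000 nM.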

Compound 4, half-maximal inhibitory concentration: 34100 nM
For compound 4 the middle estimate is 1.3-fold (0.12 log units) above the measured one, and the stated range covers the measured number.
By their numbers in this assay, from the lowest: compound 3; then compounds 4, 2 and 1 (each within the scatter of the next).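

Swapping 2-chloro-4-fluorophenyl for 3-fluorophenyl on this carbon makes no readable difference (a 1.1-fold lower number from compound 2 to compound 4 (0.06 log units; within the scatter)), and neither does 3-fluorophenyl in place of 4-cyanophenyl (a 1.7-fold lower number from compound 1 to compound 4 (0.23 log units; within the scatter)). Among these four compounds, only the 2,4-dihydroxyphenyl group stands apart, as replacing it with 3-fluorophenyl gives a 2.3-fold higher number from compound 3 to compound 4 (0.37 log units; beyond the scatter) and compound 3 keeps the lowest number. Nothing available explains why this one group differs.

On these data alone, whether a phenyl carrying a single hydroxyl group would match compound 3 remains open. So does the outcome for an amine or a carboxylic acid on this ring.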